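Ring fluorination of compound 1: expected growth inhibition

The source may report more compounds than this note shows. Statements on the series, on what has been measured and on what is new or still open speak of the compounds shown alone.

Compound 1 `N/C(=N\NC(=S)N1CCOCC1)c1ccccn1` gives 69.4% in a functional assay on A-431 cells (Homo sapiens) for cytotoxicity, read by MTT assay, with a stated time of 72 h, tested at 10 uM (a higher number here means more inhibition of growth at the concentration tested, a lower number less inhibition of growth), the highest of the three numbers shown, with the other two within the scatter of it: compound 2 `Cc1ccnc(/C(N)=N/NC(=S)N2CCOCC2)c1` gives 62% and compound 3 `N/C(=N\NC(=S)N1CCSCC1)c1ccccn1` gives 61.4%. Both measured steps, a number 7.4 percentage points lower from compound 1 to compound 2 (within the scatter) and a number 8 percentage points lower from compound 1 to compound 3 (within the scatter), stay within the scatter. Compound 4 `N/C(=N\NC(=S)N1CCOCC1)c1ccc(F)cn1` differs from compound 1 by fluoro in place of hydrogen on an aromatic carbon, on an aromatic carbon of a six-membered aromatic ring with 1 nitrogen, two atoms from the ring nitrogen, para to a large group. Among the measured compounds shown here, only the step to compound 2 bears on this, a small substituent on the same ring, and it stayed within the scatter. No step beyond the scatter is therefore expected in this assay. Compound 4 is estimated at 66% (52% to 80%). That estimate means an expected a number 3.4 percentage points lower from compound 1 to compound 4 (within the scatter).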

Compound 4, percent growth inhibition at one concentration: 66.9%
Estimate against measurement, compound 4: 0.9 percentage points below, and the stated range covers the measured number.
By their numbers in this assay, from the lowest: compounds 3, 2, 4 and 1 (each within the scatter of the next).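

In this assay, fluoro in place of hydrogen at this position, two atoms from the ring nitrogen and para to a large group, gives a number 2.5 percentage points lower from compound 1 to compound 4 (within the scatter) as its step. Among the compounds shown here, the only earlier ring change was a methyl, so this is the first sign that a halogen on this ring is also tolerated in this read-out. No measured property is available to explain this step.

Still open, as far as these compounds go, is how an amino group, a methoxy group or a carboxylic acid at this position would read in this assay. Also open, from the compounds shown here alone, is whether fluoro behaves the same way with thiomorpholin-4-yl in place of morpholin-4-yl.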